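Adding a methoxy beside the boronic acid of compound 3

This account rests on a few compounds, and the source may have more. Where it says the series, first, only, none or still open, it means among the compounds named here.

Three boronic acid stilbene analogues have been measured in a functional assay on 1-87 cells (Homo sapiens) for cytotoxicity; a lower number here means a stronger inhibitor, a higher number a weaker inhibitor. Compound 1 `COc1cc(/C=C\c2ccc(B(O)O)cc2)cc(OC)c1OC` gives 3200 nM, compound 2 `COc1cc(/C=C\c2ccc(B(O)O)cc2)cc(OC)c1` gives 9100 nM, and compound 3 `COc1cc(/C=C\c2cccc(B(O)O)c2)cc(OC)c1` gives 2000 nM. Compound 2 and compound 3 have the same atoms joined differently; the difference between the two cores is not broken down here. Compound 3 has the lowest number of the three, but its step to compound 1 lies within the scatter, so the two cannot be ordered.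

One change is already documented among the measured compounds: from compound 2 to compound 1, (methoxy in place of hydrogen on an aromatic carbon), which gave a 2.8-fold lower number from compound 2 to compound 1 (0.45 log units; beyond the scatter). The same kind of change leads from compound 3 to the unmeasured compound 4 `COc1cc(/C=C\c2ccc(OC)c(B(O)O)c2)cc(OC)c1`: methoxy in place of hydrogen on an aromatic carbon. The place is not identical: in compound 1 the new methoxy sits ortho to two methoxy groups, while in compound 4 it sits ortho to a group of 3 heavy atoms, in both cases para to a large group.

Resting only on the modest lowering from compound 2 to compound 1 and on the value of compound 3 2000 nM, a step of similar size is expected, a 2.0-fold lower number from compound 3 to compound 4 (0.30 log units; within the scatter). Compound 4 is therefore estimated at 1000 nM, with a likely range from 300 nM to 4000 nM.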

Compound 4, half-maximal inhibitory concentration: 28 nM
For compound 4 the middle estimate is 36-fold (1.55 log units) above the measured one, and the stated range ends above it.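

In this assay, within the data shown here, methoxy in place of hydrogen on an aromatic carbon gave a 71-fold lower number from compound 3 to compound 4 (1.85 log units; beyond the scatter), making compound 4 much the lowest number of the series so far. The change lowered the number on both cores, but the size of the step did not carry over from one core to the other: the same change on two cores in this assay, a 2.8-fold lower number (0.45 log units; beyond the scatter) from compound 2 to compound 1 and a 71-fold lower number (1.85 log units; beyond the scatter) from compound 3 to compound 4, 25-fold (1.40 log units) apart, beyond the scatter of two such steps

This does not show why the two steps differ, since the cores differ and the new methoxy also sits in a different place on each, here ortho to a group of 3 heavy atoms and para to a large group, so these two pairs cannot separate the role of the core from that of the place and set no rule for any other core.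

What the compounds shown leave open is whether another group in the same place, such as an ethoxy, a fluorine or an amine, would give a step of similar size. They also leave open whether a carboxylic acid in place of the boronic acid would keep compound 4 near 28 nM or not.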